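Selenium-substituted quinazoline amines: the pentyl-to-hydrogen step

The source may report more compounds than this note shows. Statements on the series, on what has been measured and on what is new or still open speak of the compounds shown alone.

Measured so far:
compound 1, `COc1ccc(CNc2nc([SeH])nc3ccccc23)cc1`: > 100000 nM
compound 2, `CCCCC[Se]c1nc(NCc2ccc(SC)cc2)c2ccccc2n1`: 35000 nM

Going by the values given here, in a functional assay on CCRF-CEM cells (Homo sapiens) for cytotoxicity, read by MTT assay, with a stated time of 72 h (on this read-out lower numbers stand for stronger inhibition of growth and higher numbers for weaker inhibition of growth), compound 2 gives 35000 nM, the only plain number in hand. Compound 1 gives > 100000 nM, which is a limit of the assay (the limit of > 100000 nM in this assay, at which 1 of the 2 values shown sits). Compound 3, `CSc1ccc(CNc2nc([SeH])nc3ccccc23)cc1`, is not yet measured; it differs from compound 2 by hydrogen in place of pentyl on a selenium. Among the compounds with values here, with no measured step of this kind, the expectation rests on compound 1, which also carries hydrogen on selenium and sits at the limit (the limit of > 100000 nM in this assay, at which 1 of the 2 values shown sits). Compound 3 is therefore expected to be weaker than compound 2, a step of a 2.6-fold higher number from compound 2 to compound 3 (0.41 log units; beyond the scatter) in this assay. The estimate for compound 3 is 90000 nM, within 30000 nM to 250000 nM.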

Compound 3, concentration for 50% growth inhibition: 71900 nM
Beside the measured number, compound 3's estimate is 1.3-fold (0.10 log units) above it; low and high end bracket the measured number.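

In this assay, the change from pentyl to hydrogen on the selenium now has a measured size: a 2.1-fold higher number from compound 2 to compound 3 (0.31 log units; beyond the scatter). With hydrogen on the selenium, compound 3 gives a plain number, whereas compound 1 stands at a limit of the assay: the limit of > 100000 nM in this assay, at which 1 of the 3 values shown sits. The exchange of methoxy for methylsulfanyl on an aromatic carbon reads as an at least 1.3-fold lower number from compound 1 to compound 3 (0.14 log units; that floor lies within the scatter), so no order of these two groups can be stated. Open, as far as these compounds go, is how an ethyl or propyl chain on the selenium compares with pentyl and hydrogen. Also open, from the compounds shown here alone, is what a terminal amine on the pentyl chain would do.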